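This account rests on a few compounds, and the source may have more. Where it says the series, first, only, none or still open, it means among the compounds named here.

Compound 1 `CNC(=O)c1cc(Oc2ccc(C(=O)/C=C/c3ccco3)cc2)ccn1`: "not determined" (no result reported)
Compound 2 `CNC(=O)c1cc(Oc2ccc(C(=O)/C=C/c3cccc(Br)c3)cc2)ccn1`: 3400 nM

Going by the values given here, in a functional assay on PC-3 cells (Homo sapiens) for cytotoxicity, read by MTT assay, with a stated time of 72 h (a higher number here means a weaker inhibitor, a lower number a stronger inhibitor), compound 2 gives 3400 nM, the only number available, as compound 1 has no result. Compound 3 `CNC(=O)c1cc(Oc2ccc(C(=O)/C=C/c3ccccc3)cc2)ccn1` follows from compound 2 through (hydrogen in place of bromo on an aromatic carbon), hydrogen in place of bromo on an aromatic carbon. Among the compounds with values here, no measured step shows what such a change does, so no shift beyond the usual scatter is expected, with a slight lean towards a weaker inhibitor. The expected step is a 1.3-fold higher number from compound 2 to compound 3 (0.12 log units; within the scatter). For compound 3 the estimated value is 4500 nM, with an expected range of 1700 nM to 12000 nM.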

Compound 3, half-maximal inhibitory concentration: 3170 nM
Compound 3: middle estimate off by 1.4-fold (0.15 log units), on the high side, and the stated range covers the measured number.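

In this assay the step with hydrogen in place of bromo on the aromatic carbon is a 1.1-fold lower number from compound 2 to compound 3 (0.03 log units; within the scatter), so the 3-bromophenyl and phenyl groups read alike at this position. This first measured step shows that compound 3 keeps a value matching that of compound 2 without the bromo. No measured evidence bears on this result. Going by these compounds, whether an amine or a carboxylic acid on this carbon would read differently remains open. So does the effect of bromo on the other carbons of this ring.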